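The compounds below may be only part of what the source reports. "The series", "measured", "known", "first", "only" and "open" are said of these compounds alone.

Within the data shown here, compound 2 `CCCCCC(=O)O[C@H]1[C@H](O)[C@H](n2ccc(N)nc2=O)O[C@@H]1CO` stands at the lowest of the two numbers measured so far: in a functional assay on HeLa cells (Homo sapiens) for cytotoxicity, read by cell counting, with a stated time of 48 h (on this read-out higher numbers stand for an effect only at larger amounts of compound and lower numbers for an effect already at smaller amounts), compound 2 gives 0.05 ug/mL. Compound 1 `CCCCCCCCCCCCCCCC(=O)O[C@H]1[C@H](O)[C@H](n2ccc(N)nc2=O)O[C@@H]1CO`, which carries the longer chain on its ester, gives 0.24 ug/mL in this assay. Among the measured compounds shown here, the single measured step, a 4.8-fold lower number from compound 1 to compound 2 (0.68 log units; beyond the scatter), shows that cutting the chain back lowered the number. Compound 3 `CCCCCCC/C=C\C(=O)O[C@H]1[C@H](O)[C@H](n2ccc(N)nc2=O)O[C@@H]1CO` differs from compound 2 by a group of 9 heavy atoms (9 carbon; no ring) in place of a group of 5 heavy atoms (5 carbon; no ring), on a carbonyl carbon, so the chain grows again, not as far as in compound 1, and now holds one double bond outside aromatic rings. The step from compound 1 to compound 2 bears on this change as the same chain lengthening in the other direction. A move back toward a higher number is therefore expected, smaller than that step, which the estimate expresses as a 2.0-fold higher number from compound 2 to compound 3 (0.30 log units; within the scatter). Compound 3 is accordingly expected to give 0.1 ug/mL in this assay, within a range from 0.04 ug/mL to 0.3 ug/mL.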

Compound 3, concentration for half-maximal effect: 0.06 ug/mL
Beside the measured number, compound 3's estimate is 1.7-fold (0.22 log units) above it; low and high end bracket the measured number.
By their numbers in this assay, from the lowest: compounds 2 and 3 (each within the scatter of the next); then compound 1.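

In this assay, putting the group of 9 heavy atoms with its double bond on the carbonyl carbon in place of pentyl gives a 1.2-fold higher number from compound 2 to compound 3 (0.08 log units; within the scatter). A longer chain at this place therefore does not by itself separate a compound from compound 2, whereas the earlier step, a 4.8-fold lower number from compound 1 to compound 2 (0.68 log units; beyond the scatter), had linked chain length to a change beyond the scatter. Nothing available explains this difference between the two steps.

Compound 3 changes chain length and adds a double bond in one step, so the compounds shown do not tell the two changes apart, and a saturated chain of 9 carbons would be needed to do so. Going by these compounds, how an amine or a carboxylic acid in place of pentyl on this carbonyl carbon would read also remains open.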